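The source may hold more compounds than are shown below. What is called first, only, known or untested is meant among the compounds shown, and "the series" means these compounds.

Of the compounds shown here, three have so far been tested in a functional assay on the whole organism (strain CD1) for inhibition, with Mus musculus as the target, with stated times of 15 min and 20 min, at a dose of 10 mg/kg by the subcutaneous route; a lower number here means less inhibition, a higher number more inhibition at the dose given (going by the name of the read-out). Compound 1 `N#C/C(=C\c1cccnc1)C(=O)O` gives -39.8%, a negative number. Compound 2 `N#C/C(=C\c1c[nH]cn1)C(=O)OC1CCCCC1` gives 50%, and compound 3 `CC(C)(C)OC(=O)/C(C#N)=C/c1cc2ccccc2[nH]1` gives 51.3%, the highest of the three numbers; its gap to compound 2 lies within the usual scatter, while its gap to compound 1 lies well beyond it. Compound 2 and compound 3 therefore give numbers near one another, and only compound 1 stands apart.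

Compound 4 `CCNC(=O)/C(C#N)=C/c1cc2ccccc2[nH]1` has not yet been measured. It differs from compound 3 in one place: ethylamino in place of tert-butoxy on a carbonyl carbon. Within the data shown here, no pair of measured compounds differs by a change of this kind, so nothing measured here shows directly what it does. For compound 4 the expected step in this assay is small and downward, a number 11.3 percentage points lower from compound 3 to compound 4 (beyond the scatter), of a size that may well stay within the scatter. Compound 4 is expected to give about 40% in this assay, with a likely range from 5% to 65%.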

Compound 4, a percentage reported as inhibition, in the whole organism at one dose (the size of the read-out at that dose, not a potency): 45%
Estimate against measurement, compound 4: 5 percentage points below, and the stated range covers the measured number.
By their numbers in this assay, from the lowest: compound 1; then compounds 4, 2 and 3 (each within the scatter of the next).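

In this assay, among these compounds, the first measured change on this carbonyl carbon comes out as a number 6.3 percentage points lower from compound 3 to compound 4 (within the scatter), so the two compounds cannot be told apart at the dose given. This position can therefore carry ethylamino, with its hydrogen-bond donor and fewer heavy atoms, in place of tert-butoxy, and the inhibition stays within the usual scatter of the reading for compound 3. No measurement shown here explains why swapping these two groups leaves the numbers so close.

A single pair cannot show whether this holds for other groups on the same carbonyl carbon, such as a longer chain like butylamino, a ring-bearing benzylamino or a small methoxy. The reading at one dose also leaves open whether compound 3 and compound 4 would still match at other doses.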